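A few compounds are considered here, and "the series" means these few. Any claim that something is new, unique, unknown or untested is made for them only; others in the source may bear on it.

Going by the values given here, in a functional assay on DU-145 cells (Homo sapiens) for cytotoxicity, read by trypan blue exclusion, with a stated time of 96 h (on this read-out lower numbers stand for stronger inhibition and higher numbers for weaker inhibition), compound 1 (`COc1cc(OC)c(/C=C/S(=O)(=O)Cc2ccc(OC)c([N+](=O)[O-])c2)c(OC)c1`) gives 2500 nM as the lower of the two numbers so far, and compound 2 (`COc1cc(OC)c(/C=C/S(=O)(=O)Cc2ccc(Br)c([N+](=O)[O-])c2)c(OC)c1`) gives 25000 nM as the higher. Compound 3 (`COC(=O)CCNc1cc(CS(=O)(=O)/C=C/c2c(OC)cc(OC)cc2OC)ccc1OC`) has no number yet. It carries (2-(methoxycarbonyl)ethyl)amino in place of nitro on an aromatic carbon, ortho to a methoxy group ((2-(methoxycarbonyl)ethyl)amino in place of nitro on an aromatic carbon). Among the compounds with values here, only one measured step bears on this, and only indirectly: bromo in place of methoxy on an aromatic carbon gave a 10-fold higher number from compound 1 to compound 2 (1.00 log units; beyond the scatter) and left the nitro untouched. That step shows that one exchange can move the number by a modest amount, but its direction does not carry over to the new group. A step of similar size is therefore expected in this assay in either direction, with a slight lean towards a lower number. The expected change is a 3.1-fold lower number from compound 1 to compound 3 (0.49 log units; beyond the scatter) as a working estimate. For compound 3 the estimated value is 800 nM within an expected range of 80 nM to 8000 nM for now.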

Compound 3, half-maximal inhibitory concentration: 1500 nM
Compound 3: middle estimate off by 1.9-fold (0.27 log units), on the low side, within the range that was stated.
By their numbers in this assay, from the lowest: compounds 3 and 1 (each within the scatter of the next); then compound 2.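

In this assay the position ortho to a methoxy group accepts a much larger group than nitro: (2-(methoxycarbonyl)ethyl)amino, with 7 heavy atoms against 3, gives a 1.7-fold lower number from compound 1 to compound 3 (0.22 log units; within the scatter) and so leaves compound 3 level with compound 1. The nitro is therefore not needed for this level of cytotoxicity, and this position, unlike the methoxy exchange in the earlier step, has so far shown no loss. Nothing available explains why the exchange is tolerated.

From the compounds shown here alone, it remains open whether a plain amine, a carboxylic acid in place of the methyl ester, or a longer chain on the nitrogen would stay at this level. Also open, going by these compounds, is whether bromo in place of methoxy, which gave a 10-fold higher number from compound 1 to compound 2 (1.00 log units; beyond the scatter) with the nitro present, would act alike with the new group.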